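The source may report more compounds than this note shows. Statements on the series, on what has been measured and on what is new or still open speak of the compounds shown alone.

Measured so far in a functional assay on MDA-MB-231 cells (Homo sapiens) for inhibition; on this read-out higher numbers stand for weaker inhibition and lower numbers for stronger inhibition:

compound 1 `O=C(/C=C/c1ccc(I)cc1)c1ccc(OCB(O)O)cc1` gives 11000 nM
compound 2 `O=C(O)COc1ccc(/C=C/C(=O)c2ccc(Cl)c(Cl)c2)cc1` gives 18000 nM
compound 3 `O=C(/C=C/c1ccc(B(O)O)cc1)c1ccc(Cl)c(Cl)c1` gives 8000 nM

Compound 1 sits between the other two numbers: its gap to compound 3 and its gap to compound 2 both lie within the usual scatter of this assay, so the three measured compounds are not separated with confidence.

The next compound, compound 4 `O=C(/C=C/c1ccc(I)cc1)c1ccc(B(O)O)cc1`, is reached from compound 1 by a change on the aromatic carbon para to the large group: a group of 3 heavy atoms (1 boron, 2 oxygen; no ring) in place of a group of 5 heavy atoms (1 carbon, 1 boron, 3 oxygen; no ring), on an aromatic carbon. In both compounds this aromatic carbon carries a boron-containing group; in compound 1 the boron is separated from the ring by a carbon and an oxygen, in compound 4 it is attached directly.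

Going by the values given here, one measured step bears on this. From compound 2 to compound 3 an oxygen-linked group on an aromatic carbon was replaced by a directly attached boronic acid group, and this assay moved by a 2.3-fold lower number from compound 2 to compound 3 (0.35 log units; beyond the scatter). The present change is of the same kind, though the leaving group differs, so a modest lowering is expected for compound 4, about a 1.6-fold lower number from compound 1 to compound 4 (0.20 log units; within the scatter), with no certainty that it will exceed the scatter.

The estimate for compound 4 in this assay is 7000 nM, with a range from 3500 nM to 14000 nM.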

Compound 4, half-maximal inhibitory concentration: 8800 nM
For compound 4 the middle estimate is 1.3-fold (0.10 log units) below the measured one; the range from low to high includes it.
By their numbers in this assay, from the lowest: compounds 3, 4, 1 and 2 (each within the scatter of the next, the first and the last beyond it).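

At the aromatic carbon para to a large group, the group of 3 heavy atoms in place of the group of 5 heavy atoms gives a 1.3-fold lower number from compound 1 to compound 4 (0.10 log units; within the scatter) in this assay, so on this core the read-out does not separate these two boron-containing groups. The earlier step, a 2.3-fold lower number from compound 2 to compound 3 (0.35 log units; beyond the scatter), replaced a group without boron and was made on a different core, whereas here boron is present on both sides of the change, and no separation beyond the scatter appears. No measurement at hand offers an explanation for this result.

The compounds shown leave open how a group without boron, such as a carboxylic acid or an amine, would read at this position on the core of compound 4, so the step from compound 2 to compound 3 has no direct counterpart on this core. Also open, from the compounds shown here alone, is whether a longer chain carrying the boron would remain within the scatter of compound 1 and compound 4 in this assay.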